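Swapping a benzodioxinyl group for a chlorophenyl in a sulfonamide series

The compounds below may be only part of what the source reports. "The series", "measured", "known", "first", "only" and "open" are said of these compounds alone.

Three compounds share a bis(trifluoromethyl)benzenesulfonamide core joined through a short amine-bearing chain to an aromatic tail. Compound 1 `O=S(=O)(NCCNCc1cccc2ccccc12)c1cc(C(F)(F)F)cc(C(F)(F)F)c1` has a naphthylmethyl tail, compound 2 `O=S(=O)(NCCNCc1ccc(-c2ccccc2)cc1)c1cc(C(F)(F)F)cc(C(F)(F)F)c1` a biphenylmethyl tail, and compound 3 `O=S(=O)(NCCCNCC1COc2ccccc2O1)c1cc(C(F)(F)F)cc(C(F)(F)F)c1` a (2,3-dihydro-1,4-benzodioxin-2-yl)methyl tail on a chain one carbon longer. In a functional assay on MCF7 cells (Homo sapiens) for inhibition, read by MTT assay, with a stated time of 72 h (a higher number here means a weaker inhibitor of growth, a lower number a stronger inhibitor of growth), compound 1 gives 18000 nM, compound 2 gives 1400 nM and compound 3 gives 2500 nM. Compound 3 thus holds the second highest of the three numbers: its gap to compound 2 lies within the scatter of this assay, while its gap to compound 1 lies beyond it.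

Compound 4 `O=S(=O)(NCCCNCc1cccc(Cl)c1)c1cc(C(F)(F)F)cc(C(F)(F)F)c1` differs from compound 3 in one place: 3-chlorophenyl in place of 2,3-dihydro-1,4-benzodioxin-2-yl on a saturated chain carbon bound to an amine nitrogen. For the measured compounds named here, no measured pair in this set isolates such a change, so the direction of the step rests on the structural change alone. Because compound 3 gives 2500 nM and the tail becomes a plain chlorinated benzyl group, the expected step of a 1.6-fold higher number from compound 3 to compound 4 (0.20 log units; within the scatter) is small, toward a somewhat higher number, likely within the scatter or only a little beyond it. Compound 4 is therefore estimated at 4000 nM, with a plausible range from 1200 nM to 13000 nM.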

Compound 4, concentration for 50% growth inhibition: 2600 nM
Estimate against measurement, compound 4: 1.5-fold (0.19 log units) above; measured number inside the range.
By their numbers in this assay, from the lowest: compounds 2, 3 and 4 (each within the scatter of the next); then compound 1.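

In this assay, the step of a 1.0-fold higher number from compound 3 to compound 4 (0.02 log units; within the scatter) lies within the scatter, so this place on the saturated chain carbon bound to an amine nitrogen accepts a very different tail with no readable effect on growth inhibition. For the compounds shown here, the six-membered non-aromatic ring with its 2 hetero atoms and the 2 hydrogen-bond acceptors of 2,3-dihydro-1,4-benzodioxin-2-yl can all leave, and a smaller 3-chlorophenyl with 0 hydrogen-bond acceptors can enter, without the number moving beyond the scatter; the earlier compounds could not show this, as no two of them differed in one place only. Nothing measured here explains why the two tails read alike.

From the compounds shown here alone, whether the chlorine matters at all remains open, since a plain phenyl or a 3-methoxyphenyl at this place would be needed to separate its contribution from that of the benzene ring it sits on. How compound 4 relates to compound 1 and compound 2 also stays unresolved, as each differs from it in both tail and chain, and a pair sharing one tail on the two chain lengths, or on a longer chain, would be needed to read the chain alone.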